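The source may report more compounds than this note shows. Statements on the series, on what has been measured and on what is new or still open speak of the compounds shown alone.

Of the compounds shown here, two with a shared core have so far been tested in a functional assay on the whole organism with Mus musculus as the target; a lower number here means that less compound is needed, a higher number that more compound is needed for the effect. Compound 1 `CCOC(=O)Nc1c(C)c(C)c2c(c1C)CC(C)(C)O2` gives only a limit, > 100 mg/kg. Among the measured compounds shown here, compound 2 `CCCNc1c(C)c(C)c2c(c1C)CC(C)(C)O2` gives 51.1 mg/kg, the only actual number in this assay so far. Compound 3 `Cc1c(C)c2c(c(C)c1Nc1ccc(Cl)cc1)CC(C)(C)O2` departs from compound 2 by one change: 4-chlorophenyl in place of propyl on a nitrogen on an aromatic ring. For the measured compounds named here, only one measured step bears on this, also on a nitrogen on an aromatic ring: an at least 1.9-fold lower number from compound 1 to compound 2 (0.29 log units; that floor lies within the scatter). Going by the values given here, that step is only a floor, and no measured step involves 4-chlorophenyl, so neither a direction nor a size beyond the scatter is expected in this assay. The expected step is a 1.1-fold lower number from compound 2 to compound 3 (0.06 log units; within the scatter). For compound 3 the estimate is 45 mg/kg, with an expected range from 14 mg/kg to 130 mg/kg.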

Compound 3, dose for 50% inhibition: > 50 mg/kg
Compound 3: no number, only a limit; the forecaster's own chance of this, stated with the estimate: 25%; middle value at least 1.1-fold (0.04 log units) away from the limit.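

In this assay compound 3 gives > 50 mg/kg, a limit and not a number, and neither its step from compound 2 nor its step from compound 1 can be read. Going by these compounds, whether 4-chlorophenyl in place of propyl on the nitrogen lowers or raises the number in this assay stays open.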